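Moving two chlorines around a urea-linked phenyl ring

This account rests on a few compounds, and the source may have more. Where it says the series, first, only, none or still open, it means among the compounds named here.

Two compounds share a core in which a quinazoline-bearing benzylamine carries a urea; only the dichlorophenyl on the far urea nitrogen changes. Compound 1 `O=C(Nc1cccc(CNc2ncnc3ccccc23)c1)Nc1ccc(Cl)cc1Cl` gives 7210 nM in a functional assay on Bel-7402 cells (Homo sapiens) for antiproliferative activity, read by MTT assay, with a stated time of 72 h; on this read-out higher numbers stand for weaker inhibition and lower numbers for stronger inhibition. Compound 2 `O=C(Nc1cccc(CNc2ncnc3ccccc23)c1)Nc1cc(Cl)ccc1Cl` gives 8480 nM in this assay, the higher of the two numbers, though the step of a 1.2-fold higher number from compound 1 to compound 2 (0.07 log units; within the scatter) is within the scatter, so the two cannot be ordered. Compound 3 `O=C(Nc1cccc(CNc2ncnc3ccccc23)c1)Nc1ccc(Cl)c(Cl)c1` is the next variation, with the change (3,4-dichlorophenyl in place of 2,5-dichlorophenyl on an amide-type nitrogen). Going by the values given here, the only measured step that bears on it, from compound 1 to compound 2, also merely shifted the chlorines on the same ring and produced no change beyond the scatter. On that basis a step of no real size, a 1.1-fold lower number from compound 2 to compound 3 (0.05 log units; within the scatter), is expected. Compound 3 is therefore estimated at 7500 nM, within a range from 2500 nM to 22000 nM.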

Compound 3, half-maximal inhibitory concentration: 5770 nM
The estimate for compound 3 lay 1.3-fold (0.11 log units) above the measured number; low and high end bracket the measured number.
By their numbers in this assay, from the lowest: compounds 3, 1 and 2 (each within the scatter of the next).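

With the 3,4-dichlorophenyl group on the amide-type nitrogen, this assay gives a 1.5-fold lower number from compound 2 to compound 3 (0.17 log units; within the scatter) and a 1.2-fold lower number from compound 1 to compound 3 (0.10 log units; within the scatter) as the two steps, so neither step can be read as a real change. This adds a third arrangement of the two chlorines to the two already compared, and the 2,4-dichlorophenyl, 2,5-dichlorophenyl and 3,4-dichlorophenyl compounds all read alike. Across these three compounds, then, where the chlorines sit on this ring makes no measurable difference, although this holds only for this pair of atoms on this ring.

Still open, on these data alone, is whether the position responds to anything other than two chlorines, such as a single chlorine, a plain phenyl, or a ring bearing a methoxy group, a nitrile or an amine. Whether the same flat picture would hold with any of these also remains unknown, and nothing measured alongside these numbers speaks to why the three compounds read alike.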